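Solubility at low pH: replacing the aminoalkyl side chain

The compounds below may be only part of what the source reports. "The series", "measured", "known", "first", "only" and "open" are said of these compounds alone.

Measured so far:
compound 1 `CNc1nc(NCCCN(C)C)c2sc(-c3ccc(C(F)(F)F)cc3)cc2n1` — 240 ug/mL
compound 2 `CNc1nc(NCCN2CCNCC2)c2sc(-c3ccc(C(F)(F)F)cc3)cc2n1` — 203 ug/mL
compound 3 `CNc1nc(NC2CCOCC2)c2sc(-c3ccc(C(F)(F)F)cc3)cc2n1` — a limit of the assay, < 5 ug/mL

In a physicochemical assay for solubility, at pH 2 (a higher number here means a more soluble compound, a lower number a less soluble compound), compound 1 stands highest of the two numbers, with compound 2 within the scatter of it; the third value is only a limit (the limit of < 5 ug/mL in this assay, at which 1 of the 3 values shown sits). Compound 4 `CNc1nc(Nc2cccc(C(N)=O)c2)c2sc(-c3ccc(C(F)(F)F)cc3)cc2n1` is not yet measured. Against compound 1 the change is 3-carbamoylphenyl in place of 3-(dimethylamino)propyl on a nitrogen on an aromatic ring. The relevant steps are a 1.2-fold lower number from compound 1 to compound 2 (0.07 log units; within the scatter), which is flat, and an at least 48-fold lower number from compound 1 to compound 3 (1.68 log units; beyond the scatter) and an at least 40-fold lower number from compound 2 to compound 3 (1.60 log units; beyond the scatter), both large drops where the 3-(dimethylamino)propyl or 2-(piperazin-1-yl)ethyl is lost for oxan-4-yl. Compound 4 also loses the 3-(dimethylamino)propyl and gains a 3-carbamoylphenyl without such a group, so a large downward step is expected, a 60-fold lower number from compound 1 to compound 4 (1.78 log units; beyond the scatter). Compound 4 is therefore estimated at 4 ug/mL, between 1 ug/mL and 15 ug/mL, quite possibly reported only as a limit.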

Compound 4, solubility: 85 ug/mL
The estimate for compound 4 lay 21-fold (1.33 log units) below the measured number, outside the stated range (above it).
By their numbers in this assay, from the lowest: compound 4; then compounds 2 and 1 (each within the scatter of the next). At a limit, below all of these: compound 3.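

In this assay, an amine in the group on this nitrogen is not required to stay clear of the limit: with 3-carbamoylphenyl the steps are only modest, a 2.8-fold lower number from compound 1 to compound 4 (0.45 log units; beyond the scatter) and a 2.4-fold lower number from compound 2 to compound 4 (0.38 log units; beyond the scatter). The two groups without an amine are far apart, an at least 17-fold higher number from compound 3 to compound 4 (1.23 log units; beyond the scatter). Compound 3 stands at a limit, so that step gives a bound and not a size: the limit of < 5 ug/mL in this assay, at which 1 of the 4 values shown sits.

Still open, from the compounds shown here alone, is which part of 3-carbamoylphenyl matters here; a plain phenyl, or a carboxylic acid in place of the carbamoyl, would separate the ring from that group.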